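This account rests on a few compounds, and the source may have more. Where it says the series, first, only, none or still open, it means among the compounds named here.

Measured in a functional assay on NCI-H460 cells (Homo sapiens) for cytotoxicity, read by MTT assay, with a stated time of 72 h; a lower number here means a stronger inhibitor, a higher number a weaker inhibitor:
- compound 1 `CCN(CC)Cc1ccc2nc(NC(=O)N/N=C/c3cn(Cc4ccc(C(C)(C)C)cc4)c4ccccc34)sc2c1` gives 1670 nM
- compound 2 `CN(C)Cc1ccc2nc(NC(=O)N/N=C/c3cn(Cc4ccc(C(C)(C)C)cc4)c4ccccc34)sc2c1` gives 810 nM
- compound 3 `CCN(CC)Cc1ccc2nc(NC(=O)N/N=C/c3cn(Cc4ccc(C)cc4)c4ccccc34)sc2c1` gives 320 nM

Compound 2 sits in the middle of these three numbers, with compound 1 higher and compound 3 lower, both gaps beyond the scatter. Compound 4 `CN(C)Cc1ccc2nc(NC(=O)N/N=C/c3cn(Cc4ccc(Cl)cc4)c4ccccc34)sc2c1` has chloro in place of tert-butyl on an aromatic carbon. The closest measured change puts methyl in place of tert-butyl and gave a 5.2-fold lower number from compound 1 to compound 3 (0.72 log units; beyond the scatter). That step carried diethylamino rather than dimethylamino, and methyl is not chloro, so it is only a rough guide. The other measured step, a 2.1-fold lower number from compound 1 to compound 2 (0.31 log units; beyond the scatter), concerns the amine and says nothing direct about this swap. A lower number is therefore expected in this assay, probably by somewhat less than the methyl step. The estimated change is a 3.5-fold lower number from compound 2 to compound 4 (0.55 log units; beyond the scatter). Compound 4 is expected at about 230 nM, with an estimated range of 80 nM to 650 nM.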

Compound 4, half-maximal inhibitory concentration: 290 nM
The estimate for compound 4 lay 1.3-fold (0.10 log units) below the measured number; low and high end bracket the measured number.
By their numbers in this assay, from the lowest: compounds 4 and 3 (each within the scatter of the next); then compound 2; then compound 1.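

In this assay chloro in place of tert-butyl gives a 2.8-fold lower number from compound 2 to compound 4 (0.45 log units; beyond the scatter) and so extends what the methyl step showed. A lower number at this position is not tied to the diethylamino group, since it also appears with dimethylamino, and the group that enters need not contain carbon: a single chlorine atom is enough. No measurement here explains why the number falls.

From the compounds shown here alone, how methyl and chloro compare on the same amine remains open. So does what a methoxy group or plain hydrogen would give at this position.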